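Swapping an Amine for an Amide on a Shared Core

The source may hold more compounds than are shown below. What is called first, only, known or untested is meant among the compounds shown, and "the series" means these compounds.

Compound 1, `CC(C)CCn1c(Cn2c(=O)n(C(C)C)c3ccccc32)nc2cc(CN(C)C)ccc21`, was tested in an ADME assay on HEp-2 cells (Homo sapiens) for cytotoxicity (on this read-out higher numbers stand for lower toxicity in this test and lower numbers for higher toxicity in this test), and gave 5650 nM. Among the three compounds measured so far, compound 1 holds the second highest number. Compound 2, `CC(C)CCn1c(Cn2c(=O)n(C(C)C)c3ccccc32)nc2ccc(CO)cc21`, gives 81600 nM in this assay, and its gap from compound 1 lies beyond the usual scatter. Compound 3, `C=C(C)n1c(=O)n(Cc2nc3cc(C(C)=O)ccc3n2CCC(C)C)c2ccccc21`, gives 740 nM, and its gap from compound 1 also lies beyond the scatter. The spread of these three results shows that changes at the outer edge of the shared core can move this read-out considerably.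

The next compound to be measured is compound 4, `CC(C)CCn1c(Cn2c(=O)n(C(C)C)c3ccccc32)nc2cc(C(=O)N(C)C)ccc21`. Compared with compound 1, it carries dimethylcarbamoyl in place of (dimethylamino)methyl on an aromatic carbon. Within the data shown here, no measured pair shows this particular exchange, so its effect is not known from the data in hand. The expected step from compound 1 to compound 4 is a 2.7-fold higher number from compound 1 to compound 4 (0.42 log units; beyond the scatter), a modest rise, though a result within the scatter would not surprise. Compound 4 is estimated to give 15000 nM in this assay, with a likely range from 4000 nM to 60000 nM.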

Compound 4, half-maximal cytotoxic concentration: 25600 nM
Compound 4: the middle estimate sits 1.7-fold (0.23 log units) below what was measured, and the stated range covers the measured number.
By their numbers in this assay, from the lowest: compound 3; then compound 1; then compound 4; then compound 2.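

On an aromatic carbon of the shared core, putting dimethylcarbamoyl in place of (dimethylamino)methyl gives a 4.5-fold higher number from compound 1 to compound 4 (0.66 log units; beyond the scatter) in this assay and so points to lower toxicity in this test. Among these compounds, this is the first pair in the set that differs in only one place, which ties a shift in this read-out to a single group exchange on this core. No measurement here explains why the number rises.

On these data alone, it remains open whether the rise follows from losing the amine or from gaining the carbonyl, and a carboxylic acid or a (diethylamino)methyl group at the same carbon could help separate the two. As far as these compounds go, whether the same exchange would give a similar step on a different core also remains open.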